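Trihydroxyphenyl for Dimethylaminophenyl in Two Related Series

The source may report more compounds than this note shows. Statements on the series, on what has been measured and on what is new or still open speak of the compounds shown alone.

Compound 1 `Cc1ccc(S(=O)(=O)/C(=C/c2c(O)cc(O)cc2O)C(=O)c2ccc(Br)cc2)cc1`: > 100000 nM
Compound 2 `Cc1ccc(S(=O)(=O)/C(=C/c2ccc(N(C)C)cc2)C(=O)c2ccc(Br)cc2)cc1`: 50000 nM
Compound 3 `CN(C)c1ccc(/C=C(/SCc2ccc(Cl)cc2Cl)C(=O)c2ccc(Cl)cc2)cc1`: 50000 nM

In a functional assay on DU-145 cells (Homo sapiens) for inhibition, read by trypan blue exclusion, with a stated time of 96 h (on this read-out lower numbers stand for stronger inhibition of growth and higher numbers for weaker inhibition of growth), compound 2 gives 50000 nM. Compound 3 gives 50000 nM, level with compound 2 at the digits shown, within the scatter. How the two cores differ is not broken down here. For compound 1 the assay reports only a limit, > 100000 nM, as noted in the limit of > 100000 nM in this assay, at which 1 of the 3 values shown sits. The change 2,4,6-trihydroxyphenyl in place of 4-(dimethylamino)phenyl on a double-bonded chain carbon bound to a double-bonded chain carbon thus made a step of an at least 2.0-fold higher number from compound 2 to compound 1 (0.30 log units; that floor lies within the scatter). The same change, (2,4,6-trihydroxyphenyl in place of 4-(dimethylamino)phenyl on a double-bonded chain carbon bound to a double-bonded chain carbon), leads to compound 4 `O=C(/C(=C\c1c(O)cc(O)cc1O)SCc1ccc(Cl)cc1Cl)c1ccc(Cl)cc1`. Given that compound 1 reached only a limit (the limit of > 100000 nM in this assay, at which 1 of the 3 values shown sits), compound 4 is expected to show a step of a 2.0-fold higher number from compound 3 to compound 4 (0.30 log units; within the scatter), and quite possibly only a limit again. Compound 4 is therefore estimated at 100000 nM, between 50000 nM and 300000 nM.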

Compound 4, concentration for 50% growth inhibition: 25000 nM
Beside the measured number, compound 4's estimate is 4.0-fold (0.60 log units) above it; the measured number lies below the stated range.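

In this assay, putting 2,4,6-trihydroxyphenyl in place of 4-(dimethylamino)phenyl gave a 2.0-fold lower number from compound 3 to compound 4 (0.30 log units; within the scatter). Set beside the earlier step, the same change did not give the same result on the two cores: the same change on two cores in this assay, an at least 2.0-fold higher number (0.30 log units; that floor lies within the scatter) from compound 2 to compound 1 and a 2.0-fold lower number (0.30 log units; within the scatter) from compound 3 to compound 4, at least 4.0-fold (0.60 log units) apart, beyond the scatter of two such steps. The value of compound 1 is a limit and not a number, so the gap between the steps is known only as a floor, and one pair on each core gives no rule for the series: the limit of > 100000 nM in this assay, at which 1 of the 4 values shown sits.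

The compounds shown leave open how a carboxylic acid or a methoxy group on a double-bonded chain carbon bound to a double-bonded chain carbon would read in this assay. They also leave open whether the two cores would part in the same way with those groups.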